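Shortening the isothiocyanate chain on an anilide linker

The compounds below may be only part of what the source reports. "The series", "measured", "known", "first", "only" and "open" are said of these compounds alone.

Of the compounds shown here, three of one core have been measured in a functional assay on NCI-H1299 cells (Homo sapiens) for inhibition, read by CCK-8 assay, with a stated time of 72 h, tested at 1 uM; a higher number here means a stronger effect of the compound at the concentration tested, a lower number a weaker effect. Compound 1 `CN(C)C(=O)c1cc2cnc(Nc3ccc(S(=O)(=O)NCCCCN=C=S)cc3)nc2n1C1CCCC1` gives 29.9%. Compound 2 `CN(C)C(=O)c1cc2cnc(Nc3ccc(S(=O)(=O)NCCCCCN=C=S)cc3)nc2n1C1CCCC1` gives 52.1%. Compound 3 `CN(C)C(=O)c1cc2cnc(Nc3ccc(C(=O)NCCCCCCN=C=S)cc3)nc2n1C1CCCC1` gives 49.4%, the second highest of the three numbers; its nearest neighbour is compound 2, within the scatter, and its furthest is compound 1, with a number 19.5 percentage points higher from compound 1 to compound 3 (beyond the scatter). Between the two higher compounds the difference is a number 2.7 percentage points lower from compound 2 to compound 3 (within the scatter).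

Compound 4 `CN(C)C(=O)c1cc2cnc(Nc3ccc(NC(=O)CCCN=C=S)cc3)nc2n1C1CCCC1` has not yet been measured. The change from compound 3 is a group of 9 heavy atoms (5 carbon, 2 nitrogen, 1 oxygen, 1 sulfur; no ring) in place of a group of 12 heavy atoms (8 carbon, 2 nitrogen, 1 oxygen, 1 sulfur; no ring), on an aromatic carbon. The group that leaves carries a longer chain between the aromatic ring and the isothiocyanate than the group that enters, and the linker is turned around.

The step that bears on chain length is a number 22.2 percentage points higher from compound 1 to compound 2 (beyond the scatter), where one more chain carbon raised inhibition. For the measured compounds named here, compound 4 goes the other way, with a chain several atoms shorter than in compound 3, so a drop of comparable size is expected rather than a gain; the linker reversal has no measured precedent here. In this assay compound 4 is expected to give 32%, within 15% to 50%, meaning an estimated step of a number 17.4 percentage points lower from compound 3 to compound 4 (beyond the scatter).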

Compound 4, a percentage reported as inhibition, at one concentration (the size of the read-out at that concentration, not a potency): 39.7%
Compound 4: middle estimate off by 7.7 percentage points, on the low side; measured number inside the range.
By their numbers in this assay, from the lowest: compounds 1, 4, 3 and 2 (each within the scatter of the next, the first and the last beyond it).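

At the aromatic carbon para to a large group, the reversed amide with the shorter chain cannot be separated from either of two neighbours in this assay (first a number 9.7 percentage points lower from compound 3 to compound 4 (within the scatter), then a number 9.8 percentage points higher from compound 1 to compound 4 (within the scatter)). It is resolved only from the longer sulfonamide chain (a number 12.4 percentage points lower from compound 2 to compound 4 (beyond the scatter)), so this position keeps measurable inhibition with the linker turned around and the chain cut back, though the new group cannot be ranked against two of the three earlier groups. No available evidence explains these steps.

Because the reversal and the shortening arrive together in one group, the compounds shown cannot assign the outcome to either change, and a reversed amide carrying a longer chain, or the original amide direction carrying the shorter chain, would separate the two. The contribution of the isothiocyanate also stays open, since every compound shown carries it and none has a primary amine or a plain alkyl end at the chain terminus instead.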